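The source may report more compounds than this note shows. Statements on the series, on what has been measured and on what is new or still open speak of the compounds shown alone.

Compound 1, `CCN(CC)c1nc(=O)c2cc(C(F)(F)F)cc([N+](=O)[O-])c2s1`; in an ADME assay on Vero cells (Chlorocebus sabaeus) for cytotoxicity, read by MTT assay, with a stated time of 72 h (a higher number here means a weaker inhibitor, a lower number a stronger inhibitor), compound 1 gives > 100000 nM, a limit of the assay rather than a number.
Compound 2, `O=c1nc(N2CCCC2)sc2c([N+](=O)[O-])cc(C(F)(F)F)cc12`; in this assay compound 2 gives > 100000 nM, again a limit and not a number.

Compound 2 therefore stands at the edge of what this assay can report, as the limit of > 100000 nM in this assay, at which 2 of the 2 values shown sit, shows. For the measured compounds named here, the only measured step, a step that the two limits leave unreadable from compound 1 to compound 2, cannot be sized because both of its ends are limits; it shows no more than that the exchange of one cyclic amine for another left the read-out beyond reach.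

Compound 3, `O=c1nc(N2CCCCC2)sc2c([N+](=O)[O-])cc(C(F)(F)F)cc12`, carries the change (piperidin-1-yl in place of pyrrolidin-1-yl on an aromatic carbon). Going by the values given here, the one step that bears on it, the step from compound 1 to compound 2, is unreadable, so no direction or size can be drawn from it; the data hold nothing that would move compound 3 away from the limit where compound 2 sits. No step beyond the scatter is expected.

For compound 3 the estimate in this assay is 200000 nM, within a range of 60000 nM to 700000 nM. The step this expectation implies, a step that the limit leaves unreadable from compound 2 to compound 3, is expected to be within the scatter.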

Compound 3, half-maximal inhibitory concentration: > 100000 nM
Compound 3: no number, only a limit; the forecaster's own chance of this, stated with the estimate: 85%; the middle value lies beyond the limit too.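

In this assay compound 3 gives > 100000 nM, again a limit of the assay and not a number. No step to compound 3 can be read, neither from compound 1 nor from compound 2, since all of them stand at the same edge: the limit of > 100000 nM in this assay, at which 3 of the 3 values shown sit.

The compounds shown leave open how far each lies beyond that limit, and whether exchanging the amine changes the read-out at all.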